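Methylating the phenol of an anilino-enone pyrazole

This account rests on a few compounds, and the source may have more. Where it says the series, first, only, none or still open, it means among the compounds named here.

The measured compounds are:
compound 1 `O=C(/C=C\Nc1ccc(F)cc1)c1cn(-c2ccccc2)nc1-c1ccccc1`, 34200 nM;
compound 2 `O=C(/C=C\Nc1ccc(O)cc1)c1cn(-c2ccccc2)nc1-c1ccccc1`, 44600 nM.

Both were tested in an ADME assay on HaCaT cells (Homo sapiens) for antiproliferative activity, read by MTT assay, with a stated time of 48 h; on this read-out lower numbers stand for stronger inhibition and higher numbers for weaker inhibition. For the measured compounds named here, on these two numbers compound 2 stands with the higher one, but its only neighbour is compound 1, and the single measured step, a 1.3-fold higher number from compound 1 to compound 2 (0.12 log units; within the scatter), lies within the scatter, so the two compounds cannot be told apart on this read-out.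

Compound 3 `COc1ccc(N/C=C\C(=O)c2cn(-c3ccccc3)nc2-c2ccccc2)cc1` has not been measured. It differs from compound 2 in one place: methyl in place of hydrogen on an oxygen on an aromatic ring, hydroxy to methoxy, so that the (4-hydroxyphenyl)amino group becomes a (4-methoxyphenyl)amino group. Going by the values given here, no measured step covers a methyl entering on an oxygen; the one step that touches this position, a 1.3-fold higher number from compound 1 to compound 2 (0.12 log units; within the scatter), was within the scatter, and nothing in the two measured compounds points to a change of any direction. The step is therefore expected to fall within the scatter, as a 1.1-fold lower number from compound 2 to compound 3 (0.05 log units; within the scatter). For compound 3 the estimate in this assay is 40000 nM, with a range from 15000 nM to 100000 nM.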

Compound 3, half-maximal inhibitory concentration: > 50000 nM
Compound 3: a limit, no number (the forecaster's own chance of this, stated with the estimate: 15%); middle value at least 1.2-fold (0.09 log units) from the limit.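

In this assay compound 3 gives no number, only a limit of the assay: the limit of > 50000 nM in this assay, at which 1 of the 3 values shown sits. The step for a methyl entering on the oxygen is an at least 1.1-fold higher number from compound 2 to compound 3 (0.04 log units; that floor lies within the scatter), and the step that exchanges the fluoro group for a methoxy group is an at least 1.4-fold higher number from compound 1 to compound 3 (0.16 log units; that floor lies within the scatter). The earlier pair gave two numbers that could not be told apart, whereas these steps add a direction with only a floor for their size: neither change brought a lower number on this read-out, and both may lie within the scatter or beyond it.

As far as these compounds go, how far the true value of compound 3 lies past the limit stays open, so the size of both steps remains unknown. Also open, from the compounds shown here alone, is whether an amine, a carboxylic acid or a longer chain such as ethoxy in place of the hydroxy, or a change elsewhere on the shared core, would give a number that stands clear of the scatter.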